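Two furanone congeners and a predicted third

The source may hold more compounds than are shown below. What is called first, only, known or untested is meant among the compounds shown, and "the series" means these compounds.

Measured compounds:
- compound 1, `CC1=C(O)[C@@H](C/C(C)=C\CCC(C)/C=C/C/C(C)=C/CCc2ccoc2)OC1=O`, giving 27.5 ug/mL in this assay
- compound 2, `CC1=C(O)/C(=C/[C@H](C)CC/C=C(/C)CCCc2coc(Cc3ccoc3)c2)OC1=O`, giving 4.74 ug/mL in this assay

The study compares two butenolide natural-product-like compounds in a functional assay on HCT-15 cells (Homo sapiens) for cytotoxicity; on this read-out higher numbers stand for an effect only at larger amounts of compound and lower numbers for an effect already at smaller amounts. Compound 1 `CC1=C(O)[C@@H](C/C(C)=C\CCC(C)/C=C/C/C(C)=C/CCc2ccoc2)OC1=O` gives 27.5 ug/mL in this assay. Compound 2 `CC1=C(O)/C(=C/[C@H](C)CC/C=C(/C)CCCc2coc(Cc3ccoc3)c2)OC1=O` gives 4.74 ug/mL in this assay, the lowest of the two numbers shown, and its gap to compound 1 lies beyond the usual scatter. Among the compounds with values here, no single-change step between compounds 1 and 2 is given, so only their two values are compared here.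

Compound 3 `CC1=C(O)/C(=C\[C@H](C)CC/C=C(/C)CCCc2coc(Cc3ccoc3)c2)OC1=O` is the untested partner of compound 2. The difference is the two compounds have the same atoms and bonds and differ only in configuration as drawn: 1 of 3 stereo elements differ; a double bond is drawn Z in compound 2 and E in compound 3. Within the data shown here, with no measured step of this kind to rest on, the expectation is that the step from compound 2 to compound 3 stays small, a 1.3-fold higher number from compound 2 to compound 3 (0.10 log units; within the scatter), in either direction or within the scatter. Compound 3 is therefore estimated at 6 ug/mL in this assay, with a range from 2 ug/mL to 18 ug/mL.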

Compound 3, concentration for half-maximal effect: 7.31 ug/mL
Estimate against measurement, compound 3: 1.2-fold (0.09 log units) below, and the stated range covers the measured number.
By their numbers in this assay, from the lowest: compounds 2 and 3 (each within the scatter of the next); then compound 1.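

Within the data shown here, compounds 2 and 3 give the first single-change comparison in this set, and in this assay it reads a 1.5-fold higher number from compound 2 to compound 3 (0.19 log units; within the scatter). On this evidence, the geometry of this one double bond does not separate the two compounds on this read-out, and the pair can be treated as equivalent within the scatter in this assay. The comparison isolates that single element, with nothing else varying between the two structures: the fact that compounds 2 and 3 differ only in the configuration as drawn.

The compounds shown leave open how the other two stereo elements bear on the read-out, and compound 1 offers no answer, as it differs from compounds 2 and 3 in more than one place. They also leave open whether an amine or a carboxylic acid on the shared core, or a longer chain in place of the present one, would give a number beyond the scatter of those of compounds 2 and 3 in this assay.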